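Mirror Image of a Weak Monoamine Oxidase A Ligand

A few compounds are considered here, and "the series" means these few. Any claim that something is new, unique, unknown or untested is made for them only; others in the source may bear on it.

In an assay on mitochondria for inhibition of Amine oxidase [flavin-containing] A (Rattus norvegicus) (on this read-out higher numbers stand for weaker inhibition and lower numbers for stronger inhibition), compound 1, `NC(=O)[C@H](CO)NCc1ccc(OCc2cccc(Cl)c2)cc1`, gives 84600 nM. Alongside it stands compound 2, `C[C@H](NCc1ccc(OCc2ccccc2)cc1)C(N)=O`, which in this assay gives 101000 nM; the two numbers lie within the scatter of each other, so neither can be called the tighter binder, and both sit in a region of very weak inhibition. The compound now in question is compound 3, `NC(=O)[C@@H](CO)NCc1ccc(OCc2cccc(Cl)c2)cc1`. Compared with compound 1 the change is the two compounds have the same atoms and bonds and differ only in configuration as drawn: 1 of 1 stereo elements differ; a stereocentre at a saturated chain carbon is drawn S in compound 1 and R in compound 3. Going by the values given here, no measured pair in this set shows what such a change does, so the direction of the step is open; a shift beyond the scatter in either direction is possible, but with both measured compounds so weak a large move is not anticipated. Compound 3 is therefore expected to come in near 100000 nM, with a range from 30000 nM to 300000 nM. The expected step is a 1.2-fold higher number from compound 1 to compound 3 (0.07 log units; within the scatter).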

Compound 3, half-maximal inhibitory concentration: 100000 nM
Estimate against measurement, compound 3: no gap at the digits printed; low and high end bracket the measured number.
By their numbers in this assay, from the lowest: compounds 1, 3 and 2 (each within the scatter of the next).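

In this assay, drawing the stereocentre at the saturated chain carbon as R rather than S gives a 1.2-fold higher number from compound 1 to compound 3 (0.07 log units; within the scatter). Going by these compounds alone, this pair is the first in the set to isolate the configuration at this position, and at this level of very weak inhibition the read-out does not tell the two mirror forms apart. The comparison bears on this centre alone because nothing else separates the two structures: the fact that compounds 1 and 3 differ only in the configuration as drawn

The compounds shown leave open whether configuration at this centre would count for anything in a compound that inhibits more strongly. They also leave open what a carboxylic acid in place of the primary amide, or a longer chain in place of the hydroxymethyl group, would do to the reading for either mirror form.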